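Following the limit from compound 2 to compound 3

The source may report more compounds than this note shows. Statements on the series, on what has been measured and on what is new or still open speak of the compounds shown alone.

Compound 1 (`COc1ccc([C@H]2CC(=O)N(Cc3cccc(C#N)c3)C2)cc1OC1CCCC1`): > 10000 nM (a limit)
Compound 2 (`COc1ccc([C@H]2CC(=O)N(c3ccc(N)cc3)C2)cc1OC1CCCC1`): > 10000 nM (a limit)

In a functional assay on HEK293 cells (Homo sapiens) for cytotoxicity (a lower number here means that less compound is tolerated, a higher number that more compound is tolerated), compound 2 gives > 10000 nM as a limit and not a number. The data stop at the limit of > 10000 nM in this assay, at which 2 of the 2 values shown sit, and give no exact value. Among the compounds with values here, the one measured step is a step that the two limits leave unreadable from compound 1 to compound 2 and so offers no size to carry forward. Compound 3 (`COc1ccc([C@H]2CC(=O)N(c3cc(N)cc(F)c3)C2)cc1OC1CCCC1`) has 3-amino-5-fluorophenyl in place of 4-aminophenyl on an amide-type nitrogen in a ring. With no measured size to go on, no step beyond the scatter is expected in this assay and no direction can be given. The estimated step is a step that the limit leaves unreadable from compound 2 to compound 3 and is expected to stay small. Compound 3 is estimated at 12000 nM (expected range 4000 nM to 30000 nM).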

Compound 3, half-maximal cytotoxic concentration: > 10000 nM
Compound 3: no number, only a limit; the forecaster's own chance of this, stated with the estimate: 85%; the middle value does not contradict the limit.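

No step can be read among compound 1, compound 2 and compound 3, since each gives only a limit: the limit of > 10000 nM in this assay, at which 3 of the 3 values shown sit.

The compounds shown leave open whether any group on the amide-type nitrogen would give an exact value in this assay.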